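The source may report more compounds than this note shows. Statements on the series, on what has been measured and on what is new or still open speak of the compounds shown alone.

Measured compounds: compound 1 `Cc1ccccc1OS(=O)(=O)c1cccc(NC(=O)NCCCCl)c1` with 27000 nM; compound 2 `O=C(NCCCCl)Nc1cccc(S(=O)(=O)Oc2ccc(O)cc2)c1` with 51000 nM.

In a functional assay on MCF7 cells (Homo sapiens) for cytotoxicity, read by sulforhodamine B assay, with a stated time of 48 h (on this read-out lower numbers stand for stronger inhibition and higher numbers for weaker inhibition), compound 1 gives 27000 nM and compound 2 gives 51000 nM; the two numbers lie within the scatter of each other, as the step of a 1.9-fold higher number from compound 1 to compound 2 (0.28 log units; within the scatter) shows. Compound 3 `CCNC(=O)Nc1cccc(S(=O)(=O)Oc2ccccc2C)c1` differs from compound 1 by hydrogen in place of chloromethyl on a saturated chain carbon, two bonds along the chain from an amide-type nitrogen. Among the compounds with values here, the only measured step concerns the group on the oxygen, not the chain, so no measured step bears on this change and the expectation rests on the structural change alone. The step of a 1.9-fold higher number from compound 1 to compound 3 (0.27 log units; within the scatter) is therefore a cautious expectation of a weaker number. Compound 3 is estimated at 50000 nM, within a range from 15000 nM to 160000 nM.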

Compound 3, half-maximal inhibitory concentration: 55000 nM
Beside the measured number, compound 3's estimate is 1.1-fold (0.04 log units) below it; the measured number falls inside the stated range.
By their numbers in this assay, from the lowest: compounds 1, 2 and 3 (each within the scatter of the next, the first and the last beyond it).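

In this assay, within the data shown here, the earlier compounds varied only the group on the oxygen, whereas compound 3 is the first change at the chain. With ethyl in place of 3-chloropropyl, the step is a 2.0-fold higher number from compound 1 to compound 3 (0.31 log units; beyond the scatter), so this position does register a change, though only a modest one. No measured evidence accounts for this difference. As far as these compounds go, what stays open is whether the chlorine or the chain length matters here, since compound 3 changes both. A plain propyl chain or a 2-chloroethyl chain at this position would separate the two.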